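Trimming the Benzyl Arm of a Piperidine Amide

A few compounds are considered here, and "the series" means these few. Any claim that something is new, unique, unknown or untested is made for them only; others in the source may bear on it.

For the measured compounds named here, compound 1 `COc1cc(N)c(Cl)cc1NC(=O)C1CCN(Cc2cccc(C)c2)CC1` is the only compound here with a full number in a functional assay on the whole organism for antagonist activity, with Mus musculus as the target; on this read-out lower numbers stand for an effect already at smaller amounts and higher numbers for an effect only at larger amounts of compound: compound 1 gives 2.4 mg/kg. Compound 2 `CCC(CC)CN1CCC(C(=O)Nc2cc(Cl)c(N)cc2OC)CC1` was also tested in this assay but returned only a limit, with compound 2 at > 10 mg/kg. The step of an at least 4.1-fold higher number from compound 1 to compound 2 (0.61 log units; beyond the scatter) is therefore at least as large as shown, resting on the limit (the limit of > 10 mg/kg in this assay, at which 1 of the 2 values shown sits). Compound 3 `CCN1CCC(C(=O)Nc2cc(Cl)c(N)cc2OC)CC1` has not yet been measured. It differs from compound 1 in one place: methyl in place of 3-methylphenyl on a saturated chain carbon bound to an amine nitrogen in a ring. Going by the values given here, the only measured step that bears on this change is the one from compound 1 to compound 2, in which the same 3-methylphenyl was exchanged, there for pentan-3-yl, and the number moved beyond the scatter toward larger doses. Compound 3 likewise gives up the 3-methylphenyl, here for methyl, so a move of comparable or greater size is expected in this assay. Compound 3 is estimated at 15 mg/kg, with a range from 4 mg/kg to 60 mg/kg. This estimate corresponds to an expected step of a 6.3-fold higher number from compound 1 to compound 3 (0.80 log units; beyond the scatter), and it is judged likely that compound 3 would again be reported only as a limit.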

Compound 3, dose for half-maximal effect: > 10 mg/kg
Compound 3 was reported as a limit; the forecaster's own chance of this, stated with the estimate: 60%; the middle value is on the limit's open side.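

In this assay, replacing 3-methylphenyl with methyl on a saturated chain carbon bound to an amine nitrogen in a ring gives an at least 4.1-fold higher number from compound 1 to compound 3 (0.61 log units; beyond the scatter), a step that rests on a limit and so marks only the smallest size the change can have. The move toward larger doses now appears with two different replacements, pentan-3-yl and methyl, and of the three compounds only compound 1, with its 3-methylphenyl, returns a full number. The two replacements cannot be ranked against each other, as the step from compound 2 to compound 3 cannot be read when both values are limits: the limit of > 10 mg/kg in this assay, at which 2 of the 3 values shown sit.

The compounds shown leave open how far compound 2 and compound 3 lie past their limits, and so how much of the change is tied to the particular replacement. They also leave open whether the aromatic ring or its methyl carries the difference, a question that an unsubstituted phenyl, a cyclohexyl or a pyridine ring at this place would address.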